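This account rests on a few compounds, and the source may have more. Where it says the series, first, only, none or still open, it means among the compounds named here.

Measured in a physicochemical assay for solubility, with a stated time of 3 days, at pH 7; a higher number here means a more soluble compound, a lower number a less soluble compound:
- compound 1 `NC(=O)c1ccc2[nH]c(-c3ccc(OCCCN4CCCCC4)cc3)nc2c1`: > 400000 nM (a limit, not a number)
- compound 2 `CC(=O)N1CCCCC1CCOc1ccc(-c2nc3cc(C(N)=O)ccc3[nH]2)cc1`: 193000 nM

Among the compounds with values here, compound 2 holds the only actual number so far. The value of compound 1 is a limit, as the limit of > 400000 nM in this assay, at which 1 of the 2 values shown sits, records.

Compound 3 `CC(=O)N1CCC(CCOc2ccc(-c3nc4cc(C(N)=O)ccc4[nH]3)cc2)CC1` has the same atoms as compound 2, joined differently: 1-acetylpiperidin-4-yl in place of 1-acetylpiperidin-2-yl on a saturated chain carbon, two bonds along the chain from an oxygen on an aromatic ring. The ring and its acetyl group stay, and 1-acetylpiperidin-4-yl takes the place of 1-acetylpiperidin-2-yl on the chain.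

Within the data shown here, the only measured step, an at least 2.0-fold lower number from compound 1 to compound 2 (0.31 log units; beyond the scatter), exchanges a different pair of groups. Among the measured compounds shown here, no measured step exchanges these two, so it is a weak guide here. From compound 2 at 193000 nM, no change beyond the scatter is expected, though the uncertainty is wide. The expected step is a 1.1-fold lower number from compound 2 to compound 3 (0.06 log units; within the scatter). For compound 3 the estimated value is 170000 nM, with an expected range from 60000 nM to 400000 nM.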

Compound 3, solubility: 2000 nM
Compound 3: middle estimate off by 85-fold (1.93 log units), on the high side; the measured number lies below the stated range.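

In this assay, the point at which the ring joins the chain turns out to matter greatly: 1-acetylpiperidin-4-yl in place of 1-acetylpiperidin-2-yl gives a 97-fold lower number from compound 2 to compound 3 (1.98 log units; beyond the scatter), although both groups have the same atoms and the same printed counts of hydrogen-bond donors and acceptors. The comparison with the group without an acetyl gives an at least 200-fold lower number from compound 1 to compound 3 (2.30 log units; beyond the scatter), which sets only a minimum size for that step. The value of compound 1 is a limit, not a number: the limit of > 400000 nM in this assay, at which 1 of the 3 values shown sits.

The compounds shown do not say why moving the attachment point has so large an effect. Going by these compounds, it also remains open whether the same gap would appear with a longer chain, or with a carboxylic acid or a free amine in place of the acetyl group.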